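The source may hold more compounds than are shown below. What is called first, only, known or untested is meant among the compounds shown, and "the series" means these compounds.

Measured so far in an ADME assay on MT4 cells (Homo sapiens) for cytotoxicity, read by MTT assay, with a stated time of 96 h; on this read-out higher numbers stand for lower toxicity in this test and lower numbers for higher toxicity in this test:
- compound 1 `O=[N+]([O-])c1ccc(-c2nc3cc(C(F)(F)F)ccc3[nH]2)cc1`: 6000 nM
- compound 2 `O=[N+]([O-])c1ccc(-c2nc3cc(C(F)(F)F)ccc3[nH]2)c([N+](=O)[O-])c1`: 9000 nM
- compound 3 `O=[N+]([O-])c1ccc(-c2nc3cc(C(F)(F)F)ccc3n2C2CCCCC2)cc1`: 49000 nM

Compound 1 holds the lowest number of the three. Its nearest neighbour is compound 2, reached by a 1.5-fold higher number from compound 1 to compound 2 (0.18 log units; within the scatter), a step that stays within the usual scatter. Its furthest neighbour is compound 3, reached by an 8.2-fold higher number from compound 1 to compound 3 (0.91 log units; beyond the scatter), a step that does stand beyond the scatter.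

The new compound is compound 4 `O=C(CN1CCCC1)Nc1ccc(-c2nc3cc(C(F)(F)F)ccc3[nH]2)cc1`. It differs from compound 1 in one place: (((pyrrolidin-1-yl)methyl)carbonyl)amino in place of nitro on an aromatic carbon. This change sits on an aromatic carbon of a six-membered aromatic ring of carbon only, the same ring that carries the added nitro in compound 2, while the change in compound 3 sits on an aromatic nitrogen of the shared core. Neither measured step replaces the nitro itself, so both bear on compound 4 only loosely. The step to compound 2 shows that adding a group to this ring left the number within the scatter; the step to compound 3 shows that a larger addition elsewhere raised the number modestly. Taken together, a small rise is expected for compound 4, around a 2.0-fold higher number from compound 1 to compound 4 (0.30 log units; within the scatter), though a step within the scatter would not surprise. Compound 4 is therefore estimated at 12000 nM, with a range from 4000 nM to 40000 nM in this assay.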

Compound 4, half-maximal cytotoxic concentration: 18000 nM
Compound 4: the middle estimate sits 1.5-fold (0.18 log units) below what was measured; the range from low to high includes it.
By their numbers in this assay, from the lowest: compounds 1, 2 and 4 (each within the scatter of the next, the first and the last beyond it); then compound 3.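

This is the first change shown that replaces the nitro itself instead of adding a group elsewhere, and in this assay it gives a 3.0-fold higher number from compound 1 to compound 4 (0.48 log units; beyond the scatter) as a modest step beyond the scatter, towards lower toxicity in this test. The position, on an aromatic carbon para to a large group, can therefore take a group of 9 heavy atoms with a five-membered non-aromatic ring and a hydrogen-bond donor in place of a nitro of 3 heavy atoms, and the cells still give a measurable number in the same general range. Nothing shown here offers a reason for the size or direction of this step.

The compounds shown leave open which part of the new group goes with the rise, whether the amide hydrogen and carbonyl or the pyrrolidine ring. A plain amine in place of the nitro, or a longer chain carrying the pyrrolidine, would help to separate those parts, and a carboxylic acid at the same carbon would show how far the number depends on the kind of group placed there.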